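The compounds below may be only part of what the source reports. "The series", "measured", "known", "first", "only" and "open" are said of these compounds alone.

Measured so far in an ADME assay on RD cells (Homo sapiens) for cytotoxicity, read by MTT assay, with a stated time of 3 days; on this read-out higher numbers stand for lower toxicity in this test and lower numbers for higher toxicity in this test:
compound 1 `CCCC[C@@H](CCn1cncn1)c1ccc(Cl)cc1`: 18.7 ug/mL
compound 2 `CCCC[C@@H](CCn1cncn1)c1ccc(C)cc1`: 56.5 ug/mL
compound 3 `Clc1ccc([C@@H](CCn2cncn2)Cc2ccccc2)cc1`: 24.4 ug/mL

Compound 1 and compound 2 share one core and differ only by methyl in place of chloro on an aromatic carbon; this change gives a 3.0-fold higher number from compound 1 to compound 2 (0.48 log units; beyond the scatter). Compound 3 carries a different core; the difference between the core of compound 3 and the core of compound 1 is not broken down here. In this assay compound 3 stands nearest to compound 1, within the scatter, and furthest from compound 2, beyond the scatter.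

Compound 4 `Cc1ccc([C@@H](CCn2cncn2)Cc2ccccc2)cc1` is not yet measured. It differs from compound 3 by methyl in place of chloro on an aromatic carbon, the same change that leads from compound 1 to compound 2, and at the same kind of place on the ring. For the measured compounds named here, the step from compound 3 to compound 4 in this assay is expected to be about a 2.4-fold higher number from compound 3 to compound 4 (0.38 log units; beyond the scatter), resting on the single earlier instance a 3.0-fold higher number from compound 1 to compound 2 (0.48 log units; beyond the scatter); with only one precedent on a different core, the range is kept wide. Compound 4 is therefore estimated at 58 ug/mL, between 28 ug/mL and 120 ug/mL.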

Compound 4, half-maximal cytotoxic concentration: 109 ug/mL
Estimate against measurement, compound 4: 1.9-fold (0.27 log units) below; low and high end bracket the measured number.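

In this assay, methyl in place of chloro again gives a higher number, a 4.5-fold higher number from compound 3 to compound 4 (0.65 log units; beyond the scatter), so the direction of the change carries over from the core of compound 1 to the core of compound 3. The two instances also agree in size: the same change on two cores in this assay, a 3.0-fold higher number (0.48 log units; beyond the scatter) from compound 1 to compound 2 and a 4.5-fold higher number (0.65 log units; beyond the scatter) from compound 3 to compound 4, 1.5-fold (0.17 log units) apart, within the scatter of two such steps. For the compounds shown here, this covers only two cores and one place on the ring, so it supports carrying the change between these two pairs, but it does not show that the change would hold on a further core, and it does not explain why the number moves.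

On these data alone, only chloro and methyl appear at this place, so it remains open how fluoro, methoxy, trifluoromethyl or a plain hydrogen there would compare, and whether the step reflects the arrival of methyl or the departure of chloro. Also open, as far as these compounds go, is whether the same step would appear on a core carrying a longer chain, an amine or a carboxylic acid.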